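Swapping a Fluoropyridine for a Tolyl Group on the Tetrazole

The source may hold more compounds than are shown below. What is called first, only, known or untested is meant among the compounds shown, and "the series" means these compounds.

The series shares one core, seen in compound 1 `Cc1cc(NC(=O)Cn2nnc(-c3cc(Cl)cc(Cl)c3)n2)n(C2CCCCC2)n1`, compound 2 `Cc1cc(NC(=O)Cn2nnc(-c3cccc(F)n3)n2)n(C2CCCCC2)n1` and the still unmeasured compound 3 `Cc1ccc(-c2nnn(CC(=O)Nc3cc(C)nn3C3CCCCC3)n2)cc1`. In an assay on HEK293 cells for activation of Kir3.1/Kir3.2 (Homo sapiens), read by thallium flux (on this read-out higher numbers stand for an effect only at larger amounts of compound and lower numbers for an effect already at smaller amounts), compound 1 gives 980 nM. For compound 2, this assay reports only a limit, > 3000 nM, so compound 2 stands at the weak end of the two numbers shown. Going by the values given here, the single measured step, an at least 3.0-fold higher number from compound 1 to compound 2 (0.48 log units; beyond the scatter), rests on that limit, as recorded in the limit of > 3000 nM in this assay, at which 1 of the 2 values shown sits. Compound 3 differs from compound 2 by 4-methylphenyl in place of 6-fluoropyridin-2-yl on an aromatic carbon. This change brings in a ring of carbon only, the kind of ring that compound 1 carries with its 980 nM, and removes the ring that compound 2 carries. Among the compounds with values here, the step measured so far is the only guide, and it was at least modest; going back toward a carbon-only ring leads to the expectation of a lower number, an at least 2.0-fold lower number from compound 2 to compound 3 (0.30 log units; that floor lies within the scatter). Compound 3 is therefore estimated at 1500 nM, within 500 nM to 5000 nM, though a further limit remains possible.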

Compound 3, half-maximal effective concentration: 111 nM
Compound 3: middle estimate off by 14-fold (1.13 log units), on the high side; the whole stated range lies above it.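

At this position, on an aromatic carbon of a five-membered aromatic ring with 4 nitrogen, the change from 6-fluoropyridin-2-yl to 4-methylphenyl in this assay gives an at least 27-fold lower number from compound 2 to compound 3 (1.43 log units; beyond the scatter), which carries the series past the level of the 3,5-dichlorophenyl group rather than merely back to it. The two carbon-only rings also differ from each other, with 4-methylphenyl in place of 3,5-dichlorophenyl giving an 8.8-fold lower number from compound 1 to compound 3 (0.95 log units; beyond the scatter), so a ring of carbon only does not by itself set the value. The first of these steps marks a floor and not a measured size, as compound 2 stands only as a limit: the limit of > 3000 nM in this assay, at which 1 of the 3 values shown sits.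

Going by these compounds, whether the gain belongs to the methyl group itself or to the absence of the two chlorine atoms stays open, as does whether the ring nitrogen or the fluorine of compound 2 weighs more. The compounds shown also leave open how an unsubstituted phenyl ring, or a methoxy, ethyl or trifluoromethyl group in place of that methyl, would read in this assay.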